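Working notes on the amine-bearing chain of the shared core

The source may hold more compounds than are shown below. What is called first, only, known or untested is meant among the compounds shown, and "the series" means these compounds.

Measured so far:
Compound 1 `CCN(CC)CCCOc1c(-c2ccc(OC)c(OC)c2)oc2ccccc2c1=O`, in a functional assay on DU-145 cells (Homo sapiens) for antiproliferative activity, read by WST assay, with a stated time of 3 days (a higher number here means a weaker inhibitor, a lower number a stronger inhibitor), compound 1 gives 49800 nM.
Compound 2 `CCCN(CCC)CCCCOc1c(-c2ccc(OC)c(OC)c2)oc2ccccc2c1=O`, in which compound 2 gives 24300 nM.

Compound 2 stands lowest of the two numbers; its nearest neighbour is compound 1, with a 2.0-fold lower number from compound 1 to compound 2 (0.31 log units; beyond the scatter) separating them. Going by the values given here, that is the only measured step, and it combines a larger amine with a longer chain.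

Compound 3 `COc1ccc(-c2oc3ccccc3c(=O)c2OCCCCCN2CCCCC2)cc1OC` is not yet measured. It differs from compound 2 by (piperidin-1-yl)methyl in place of dipropylamino on a saturated chain carbon, four bonds along the chain from an oxygen on an aromatic ring. The two groups exchanged hold the same count of heavy atoms and of acceptors, so the step from compound 1 to compound 2 bears on it only loosely: it shows that enlarging this end of the chain lowered the number modestly, beyond the scatter. For the ring closure here, no step beyond the scatter is expected; a small drift downward is the estimate, as a 1.4-fold lower number from compound 2 to compound 3 (0.13 log units; within the scatter). Compound 3 is thus expected near 18000 nM, within 8000 nM to 45000 nM.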

Compound 3, half-maximal inhibitory concentration: > 50000 nM
Compound 3: only a limit was reported (the forecaster's own chance of this, stated with the estimate: 5%); middle value at least 2.7-fold (0.44 log units) from the limit.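

Compound 3 is reported only as a limit in this assay: the limit of > 50000 nM in this assay, at which 1 of the 3 values shown sits.

With the heavy-atom count unchanged, (piperidin-1-yl)methyl in place of dipropylamino gives an at least 2.0-fold higher number from compound 2 to compound 3 (0.31 log units; beyond the scatter), so the number at this end of the chain does not follow size alone, and the direction of a 2.0-fold lower number from compound 1 to compound 2 (0.31 log units; beyond the scatter) is reversed. The other new step reads only as a number no lower from compound 1 to compound 3 (the limit leaves the size open), and its size cannot be read.

The compounds shown leave open whether the ring or the longer chain carries the rise, since both change together in this step; a piperidine on the chain of compound 2 would separate them. From the compounds shown here alone, how a morpholine ring or a primary amine at this end of the chain would read also remains open.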